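Replacing 4-(tert-butyl)phenyl with 2-(4-methoxyphenyl)ethenyl

This account rests on a few compounds, and the source may have more. Where it says the series, first, only, none or still open, it means among the compounds named here.

Measured so far:
Compound 1 `CCOc1cccc(-c2ccc(CN(C(=O)C(C)C)c3cccc(/C=C/C(=O)OC)c3)cc2)c1` gives 173 nM in an assay on isolated protein with Bile acid receptor (Homo sapiens) as the target; on this read-out higher numbers stand for an effect only at larger amounts of compound and lower numbers for an effect already at smaller amounts.
Compound 2 `COC(=O)/C=C/c1cccc(N(Cc2ccc(-c3ccc(C(C)(C)C)cc3)cc2)C(=O)C2CCCCC2)c1` gives 132 nM in this assay.
Compound 3 `COC/C=C/c1cccc(N(Cc2ccc(/C=C/C(=O)OC(C)(C)C)cc2)C(=O)C2CCCCC2)c1` gives 243 nM in this assay.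

Compound 2 has the lowest of these three numbers, yet both compound 1 and compound 3 lie within the usual scatter of it, so no ordering among them can be claimed. Compound 4 `COC(=O)/C=C/c1cccc(N(Cc2ccc(/C=C/c3ccc(OC)cc3)cc2)C(=O)C2CCCCC2)c1` has not been measured. It differs from compound 2 at a single place: 2-(4-methoxyphenyl)ethenyl in place of 4-(tert-butyl)phenyl on an aromatic carbon. For the measured compounds named here, no pair of measured compounds differs only at this place, so nothing measured speaks directly to this change. The expectation for compound 4 is therefore a step from compound 2 of about a 1.3-fold higher number from compound 2 to compound 4 (0.11 log units; within the scatter), not beyond the scatter, in either direction. Compound 4 is estimated at 170 nM, with a range from 60 nM to 500 nM.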

Compound 4, half-maximal effective concentration: 208 nM
Estimate against measurement, compound 4: 1.2-fold (0.09 log units) below, within the range that was stated.
By their numbers in this assay, from the lowest: compounds 2, 1, 4 and 3 (each within the scatter of the next).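

In this assay, the change at this place gives a 1.6-fold higher number from compound 2 to compound 4 (0.20 log units; within the scatter) and so does not separate the two groups. For the compounds shown here, this is the first direct look at the position: a group carrying an oxygen, a hydrogen-bond acceptor and a double bond outside the ring can replace an all-carbon group of equal heavy-atom count without a change beyond the scatter. No measurement here offers an explanation for this result. The compounds shown cannot say whether the double bond or the methoxy group matters on its own. They also leave open how an amine or a carboxylic acid would fare at this place.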